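Moving One Fluorine Atom Around a Ring

A few compounds are considered here, and "the series" means these few. Any claim that something is new, unique, unknown or untested is made for them only; others in the source may bear on it.

Of the compounds shown here, three have so far been tested in a functional assay on WM 266-4 cells (Homo sapiens) for inhibition, read by MTT assay, with a stated time of 24 h; on this read-out lower numbers stand for stronger inhibition of growth and higher numbers for weaker inhibition of growth. Compound 1 `COc1ccc(C2CC(c3ccc(Br)cc3)=NN2C(=O)C2COc3ccccc3O2)cc1` gives 9010 nM and compound 3 `COc1ccc(C2=NN(C(=O)C3COc4ccccc4O3)C(c3ccc(F)cc3)C2)cc1` gives 6190 nM, while compound 2 `O=C(c1ccc2c(c1)OCCO2)N1N=C(c2ccccc2)CC1c1ccccc1F` gives 2500 nM, the lowest of the three numbers, with its steps to both other compounds lying beyond the usual scatter. Compound 4 `O=C(c1ccc2c(c1)OCCO2)N1N=C(c2ccccc2)CC1c1cccc(F)c1` has the same atoms as compound 2, joined differently: 3-fluorophenyl in place of 2-fluorophenyl on a saturated ring carbon. Among the measured compounds shown here, no measured pair shows this change, so there is no direct guide to its size or direction. The change is expected to bring a small step, most likely one that stays within the scatter, a 1.2-fold higher number from compound 2 to compound 4 (0.08 log units; within the scatter). On that basis compound 4 is estimated at 3000 nM, with a range from 1000 nM to 9000 nM.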

Compound 4, concentration for 50% growth inhibition: 1840 nM
Beside the measured number, compound 4's estimate is 1.6-fold (0.21 log units) above it; measured number inside the range.
By their numbers in this assay, from the lowest: compounds 4 and 2 (each within the scatter of the next); then compounds 3 and 1 (each within the scatter of the next).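

In this assay the shift from 2-fluorophenyl to 3-fluorophenyl on the saturated ring carbon gives a 1.4-fold lower number from compound 2 to compound 4 (0.13 log units; within the scatter) and so stays within the usual scatter of repeated measurements. Among the compounds shown here, this is the first direct comparison at this position, and it shows that these two placements of the fluorine cannot be told apart here. Nothing available explains this result.

As far as these compounds go, whether a larger alteration at this carbon would move the number beyond the scatter remains open. A phenyl ring bearing an amine or a carboxylic acid would be one such test.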